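A few compounds are considered here, and "the series" means these few. Any claim that something is new, unique, unknown or untested is made for them only; others in the source may bear on it.

Compound 1 `O=C(NCc1cccc2ccccc12)N1C(=O)c2ccccc2S1(=O)=O`: > 166 h
Compound 2 `O=C(NCc1ccccc1F)N1C(=O)c2ccccc2S1(=O)=O`: > 166 h
Compound 3 `O=C(c1ccccc1)N1C(=O)c2ccccc2S1(=O)=O`: > 0.875 h

All three readings come from a physicochemical assay for pharmacokinetics (a lower number here means that the compound disappears faster, a higher number that the compound lasts longer), and none of them is an exact number. Compound 2 stands at > 166 h, which is a limit of the assay. Compound 1 shares that limit, as the limit of > 166 h in this assay, at which 2 of the 3 values shown sit, records. Compound 3 has a limit of its own, as the limit of > 0.875 h in this assay, at which 1 of the 3 values shown sits, records.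

Compound 4 `COc1ccccc1CNC(=O)N1C(=O)c2ccccc2S1(=O)=O` carries methoxy in place of fluoro on an aromatic carbon, ortho to a large group: methoxy in place of fluoro on an aromatic carbon. For the measured compounds named here, no measured pair in this assay shows this change, so the expectation rests on compound 2 and its limit of > 166 h. The expected step, a step that the limit leaves unreadable from compound 2 to compound 4, is none beyond the scatter. For compound 4 the estimated half-life is 170 h, with an expected range of 85 h to 340 h.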

Compound 4, half-life: > 166 h
Compound 4: a limit, no number (the forecaster's own chance of this, stated with the estimate: 75%); the middle value does not contradict the limit.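

In this assay compound 4 gives > 166 h, which is a limit. For the compounds shown here, compound 2 gives > 166 h, also a limit, and no step between compound 2 and compound 4 can be read. The compounds shown leave open whether methoxy in place of fluoro on an aromatic carbon changes the half-life at all.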